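This account rests on a few compounds, and the source may have more. Where it says the series, first, only, none or still open, it means among the compounds named here.

Compound 1 (`CCOc1c(OC)c(OC)cc2c1C(=O)[C@]1(OC)C=C[C@H]2N(C(=O)OCC(C)C)N1C(=O)OCC(C)C`) and compound 2 (`COc1cc2c(c(OCc3ccc(F)cc3)c1OC)C(=O)[C@]1(OC)C=C[C@H]2N(C(=O)OCC(C)C)N1C(=O)OCC(C)C`) share one core. In an ADME assay on KB cells (Homo sapiens) for cytotoxicity (on this read-out lower numbers stand for an effect already at smaller amounts and higher numbers for an effect only at larger amounts of compound), compound 1 gives > 300 ug/mL as a limit of the assay, not a number. Compound 2 gives > 300 ug/mL as well, again only a limit. For the measured compounds named here, the only measured step here is a step that the two limits leave unreadable from compound 1 to compound 2 and it offers no size to carry forward. What remains is the limit of > 300 ug/mL in this assay, at which 2 of the 2 values shown sit, and no true number. Compound 3 (`COc1ccc(COc2c(OC)c(OC)cc3c2C(=O)[C@]2(OC)C=C[C@H]3N(C(=O)OCC(C)C)N2C(=O)OCC(C)C)cc1`) differs from compound 2 by methoxy in place of fluoro on an aromatic carbon, para to a large group (methoxy in place of fluoro on an aromatic carbon). No sizeable step is expected in this assay because compound 2 gives > 300 ug/mL as a limit, and compound 3 is expected to stop at that same limit. The estimated step reads a step that the limit leaves unreadable from compound 2 to compound 3 for this change. Should a number appear, the value expected for compound 3 is 350 ug/mL (estimated range from 150 ug/mL to 700 ug/mL).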

Compound 3, concentration for half-maximal effect: 47.9 ug/mL
Compound 3: middle estimate off by 7.3-fold (0.86 log units), on the high side; measured number outside the range, below it.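

In this assay, methoxy in place of fluoro on an aromatic carbon, para to a large group, gives an at least 6.2-fold lower number from compound 2 to compound 3 (0.79 log units; beyond the scatter). For the compounds shown here, this is the first change here that produces a readable number, and it shows that the far end of the (4-methoxybenzyl)oxy group matters: the effect appears at smaller amounts of compound with methoxy there, whereas fluoro in the same place gave no number. Measured against the smaller group of compound 1, the same compound gives an at least 6.2-fold lower number from compound 1 to compound 3 (0.79 log units; beyond the scatter), and the earlier pair could show nothing of the kind: the limit of > 300 ug/mL in this assay, at which 2 of the 3 values shown sit.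

Going by these compounds, the true size of both steps stays open, as compound 1 and compound 2 carry only limits and not numbers. On these data alone, whether an amine, a carboxylic acid or a longer chain in this para place would behave like methoxy also remains unknown.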